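This account rests on a few compounds, and the source may have more. Where it says the series, first, only, none or still open, it means among the compounds named here.

Compound 2 `CCCCCC/C(=N\OCCCCC)c1cc(OC)c2c(c1OC)C(=O)C=CC2=O` was tested in a functional assay on A549 cells (Homo sapiens) for antiproliferative activity (on this read-out lower numbers stand for an effect already at smaller amounts and higher numbers for an effect only at larger amounts of compound), where it reaches only a limit of the assay, > 10 ug/mL. Compound 1 `CCCCCCCO/N=C(\CCCCCC)c1cc(OC)c2c(c1OC)C(=O)C=CC2=O` likewise gives only a limit in this assay, > 10 ug/mL. The step that the two limits leave unreadable from compound 1 to compound 2 is therefore not readable, and the only pointer available is the limit of > 10 ug/mL in this assay, at which 2 of the 2 values shown sit. Compound 3 `CCCCCC/C(=N\OC)c1cc(OC)c2c(c1OC)C(=O)C=CC2=O` differs from compound 2 by hydrogen in place of butyl on a saturated chain carbon bound to an oxygen. With no readable step to draw on, compound 3 is expected to stay near that limit, an estimated step that the limit leaves unreadable from compound 2 to compound 3. The estimate for compound 3 is 15 ug/mL, within 5 ug/mL to 40 ug/mL.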

Compound 3, concentration for half-maximal effect: > 10 ug/mL
Compound 3 ended at the assay's limit (the forecaster's own chance of this, stated with the estimate: 75%); the middle value does not contradict the limit.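

Compound 3 gives only a limit, as do compound 1 and compound 2, so no step among them can be read: the limit of > 10 ug/mL in this assay, at which 3 of the 3 values shown sit.

The compounds shown leave open whether the length of the chain on the oxygen matters at all in this assay.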